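A few compounds are considered here, and "the series" means these few. Any claim that something is new, unique, unknown or untested is made for them only; others in the source may bear on it.

Measured so far in a functional assay on HEK293 cells for agonist activity at D(4) dopamine receptor (Homo sapiens), read by FLIPR; a higher number here means that more compound is needed for the effect, a lower number that less compound is needed:
- compound 1, `Cc1cccc(C(=O)NCN2CCC(c3nccs3)CC2)c1`: 9.8 nM
- compound 2, `O=C(CN1CCC(c2cccc[n+]2[O-])CC1)NC1CCCCC1`: 294 nM
- compound 3, `Cc1ccc(Cl)c(NC(=O)CN2CCC(c3cccc[n+]3[O-])CC2)c1Cl`: 346 nM

Compound 1 stands lowest of the three numbers in this assay. Its nearest neighbour is compound 2, whose number is higher by a margin beyond the scatter; compound 3 lies further still, also beyond the scatter. Compounds 2 and 3 share the same ring group on the saturated ring carbon but carry different amide portions and a different link to the ring nitrogen, so neither gives a direct reading of that ring group against compound 1.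

Compound 4, `Cc1cccc(C(=O)NCN2CCC(c3cccc[n+]3[O-])CC2)c1`, is not yet measured. It differs from compound 1 in one place: a group of 7 heavy atoms (5 carbon, 1 nitrogen, 1 oxygen; one six-membered aromatic ring with 1 hetero atom) in place of a group of 5 heavy atoms (3 carbon, 1 nitrogen, 1 sulfur; one five-membered aromatic ring with 2 hetero atoms), on a saturated ring carbon. For the measured compounds named here, the entering group is the one present in compounds 2 and 3, whose values in this assay both sit well above compound 1.

Because compound 2 gives 294 nM and compound 3 gives 346 nM with the entering group in place, a rise for compound 4 is expected, though their other differences leave the size uncertain. The expected step is a 6.1-fold higher number from compound 1 to compound 4 (0.79 log units; beyond the scatter), in the direction of a higher number. For compound 4 the estimate in this assay is 60 nM, with a range from 15 nM to 300 nM.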

Compound 4, half-maximal effective concentration: 89 nM
For compound 4 the middle estimate is 1.5-fold (0.17 log units) below the measured one, and the stated range covers the measured number.
By their numbers in this assay, from the lowest: compound 1; then compound 4; then compounds 2 and 3 (each within the scatter of the next).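

In this assay, for the compounds shown here, the exchange of 1,3-thiazol-2-yl for the six-membered aromatic ring group on the saturated ring carbon gives a 9.1-fold higher number from compound 1 to compound 4 (0.96 log units; beyond the scatter) as the first reading of this change with the rest of the molecule held fixed. The step lies beyond the scatter, so the number at this position depends on the group carried there, and with the amide portion and link of compound 1 kept in place, 1,3-thiazol-2-yl is the group of the pair with the lower number. No measurement at hand accounts for the size or direction of this step.

Compounds 2 and 3 have no partner carrying 1,3-thiazol-2-yl among the compounds shown, and whether the step keeps its size or direction with their amide portions stays open. Also open, as far as these compounds go, is how other groups on this saturated ring carbon would read, such as phenyl, pyridin-2-yl or 1,3-oxazol-2-yl, and with a single step in hand, no trend across groups at this position can yet be stated.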